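From compound 3 to compound 4: a methoxymethoxy end group

The source may hold more compounds than are shown below. What is called first, only, known or untested is meant among the compounds shown, and "the series" means these compounds.

In a functional assay on MCF7 cells (Homo sapiens) for inhibition, read by MTT assay, with a stated time of 3 days (a lower number here means a stronger inhibitor, a higher number a weaker inhibitor), compound 1 `COc1ccc(COc2cc(/C=C\c3cc(OC)c(OC)c(OC)c3)ccc2OC)cc1` gives 48000 nM, compound 2 `COc1ccc(/C=C\c2cc(OC)c(OC)c(OC)c2)cc1OCc1ccc(Br)cc1` gives 29000 nM and compound 3 `COc1ccc(/C=C/CCCOc2cc(/C=C\c3cc(OC)c(OC)c(OC)c3)ccc2OC)cc1` gives 16000 nM. Compound 3 is separated from compound 1 alone: a 3.0-fold lower number from compound 1 to compound 3 (0.48 log units; beyond the scatter) is a modest step beyond the scatter, whereas a 1.8-fold lower number from compound 2 to compound 3 (0.26 log units; within the scatter) stays within it.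

Compound 4 `COCOc1ccc(/C=C/CCCOc2cc(/C=C\c3cc(OC)c(OC)c(OC)c3)ccc2OC)cc1` carries 4-(methoxymethoxy)phenyl where compound 3 carries 4-methoxyphenyl. The change is methoxy in place of hydrogen on a saturated chain carbon bound to an oxygen on an aromatic ring.

For the measured compounds named here, no measured step makes this exact change, so the evidence is indirect. Going by the values given here, the nearest precedent is the swap of bromo for methoxy on an aromatic carbon, and a 1.7-fold lower number from compound 1 to compound 2 (0.22 log units; within the scatter) remained within the scatter. The larger replacement of the whole group on the chain produced only the modest 3.0-fold lower number from compound 1 to compound 3 (0.48 log units; beyond the scatter). A smaller edit to compound 3 is therefore not expected to move the number beyond the scatter in either direction, although the data contain no direct test of a methoxymethoxy group.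

The expected result is a 1.1-fold higher number from compound 3 to compound 4 (0.05 log units; within the scatter), which would be no real change. Compound 4 is estimated at 18000 nM, with an expected range of 8000 nM to 40000 nM.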

Compound 4, half-maximal inhibitory concentration: 42000 nM
Compound 4: the middle estimate sits 2.3-fold (0.37 log units) below what was measured; the measured number lies above the stated range.
By their numbers in this assay, from the lowest: compounds 3, 2, 4 and 1 (each within the scatter of the next, the first and the last beyond it).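

The end group of the chain substituent is not a silent place in this series: going from 4-methoxyphenyl to 4-(methoxymethoxy)phenyl, an edit that adds only 2 heavy atoms, gives a 2.6-fold higher number from compound 3 to compound 4 (0.42 log units; beyond the scatter) in this assay. This step is modest, but it runs opposite to the other modest step into this chain series, a 3.0-fold lower number from compound 1 to compound 3 (0.48 log units; beyond the scatter), so the advantage of compound 3 over compound 1 cannot be read as belonging to the chain alone and depends at least partly on what sits at its end. No measurement at hand accounts for the loss seen with the methoxymethoxy group, and this single pair gives direction and size only, with no explanation.

The compounds shown do not separate the effect of added length at this end from that of the added oxygen, a question that an ethoxy or propoxy end group would address, while a hydroxy group or an amine in the same place would test a different kind of end group. Also open, from the compounds shown here alone, is whether the methoxymethoxy group would give a step of similar size and direction on the aromatic ring of compound 1.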